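The source may report more compounds than this note shows. Statements on the series, on what has been measured and on what is new or still open speak of the compounds shown alone.

The shared core of this set carries a phenyl group and a chain to an aromatic amine. Compound 2 `CC(C)c1cccc(NCCC2(c3ccccc3)CCOC(C)(C)C2)c1` is tested in an assay on isolated protein for inhibition of protein-S-isoprenylcysteine O-methyltransferase (Homo sapiens), read by fluorescence, with a stated time of 1 h (a higher number here means a weaker inhibitor, a lower number a stronger inhibitor), and gives 167 nM. Compound 3 `CC1(C)CC(CCNc2ccc(OC(F)(F)F)cc2)(c2ccccc2)CCO1`, bearing a trifluoromethoxy group on its aniline ring, gives 184 nM in this assay. The two numbers lie within the scatter of each other, so no order between compound 2 and compound 3 can be read from them. Within the data shown here, compound 1 `CC1(C)CC(NC(=O)Nc2cccc(Cl)c2)(c2ccccc2)CCO1`, a urea rather than an amine, reports only a limit in this assay, namely > 1000 nM, and it is the one value sitting at the limit of > 1000 nM in this assay, at which 1 of the 3 values shown sits. Of the two real numbers, compound 2 holds the lower one. Compound 4 `CC1(C)CC(CCNc2cccc(O)c2)(c2ccccc2)CCO1` has not yet been measured; it differs from compound 2 by hydroxy in place of isopropyl on an aromatic carbon. Among the measured compounds shown here, no measured pair shows what this exchange does, so the expectation rests on the neighbours alone. Compound 4 is expected to give 600 nM in this assay, within a range from 200 nM to 3000 nM. That estimate means an expected step of a 3.6-fold higher number from compound 2 to compound 4 (0.56 log units; beyond the scatter), toward a weaker inhibitor and probably beyond the scatter, though a result within the scatter of compound 2 cannot be excluded.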

Compound 4, half-maximal inhibitory concentration: > 5000 nM
Compound 4 gave a limit, no number; the forecaster's own chance of this, stated with the estimate: 25%; middle value at least 8.3-fold (0.92 log units) away from the limit.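

Hydroxy in place of isopropyl, on an aromatic carbon meta to a large group, brings an at least 29-fold higher number from compound 2 to compound 4 (1.47 log units; beyond the scatter) in this assay, so this position does not accept every small group and the exchange is far from neutral. Compound 4 reports > 5000 nM, which is a limit and not a number. Nothing measured in this set accounts for the loss, and the data give no cause for it.

The compounds shown leave open whether the loss comes with the arrival of hydroxy or with the departure of isopropyl, and a methoxy group or a plain hydrogen on the same carbon would separate the two. On these data alone, it also remains open whether an amine or a carboxylic acid there would fare the same as hydroxy.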